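The source may hold more compounds than are shown below. What is called first, only, known or untested is meant among the compounds shown, and "the series" means these compounds.

In a functional assay on the whole organism (strain Wistar) for inhibition, with Rattus norvegicus as the target, read by paw edema, with a stated time of 3 h, at a dose of 10 mg/kg by the intraperitoneal route (on this read-out lower numbers stand for less inhibition and higher numbers for more inhibition at the one dose given (going by the name of the read-out)), compound 1 `O=C(N/N=C/c1ccc(O)cc1)c1cccnc1Nc1cccc(C(F)(F)F)c1` gives 59.5% and compound 2 `COc1ccc(/C=N/NC(=O)c2cccnc2Nc2cccc(C(F)(F)F)c2)cc1OC` gives 44%. Compound 2 stands lowest of the two numbers shown; the nearest is compound 1, and the step of a number 15.5 percentage points lower from compound 1 to compound 2 (beyond the scatter) runs toward less inhibition. Compound 3 `O=C(N/N=C/c1cccnc1)c1cccnc1Nc1cccc(C(F)(F)F)c1` is not yet measured; it differs from compound 2 in one place: pyridin-3-yl in place of 3,4-dimethoxyphenyl on a carbon with a double bond to nitrogen. Among the measured compounds shown here, only the step from compound 1 to compound 2 bears on this change, as it swapped the group on the same carbon with a double bond to nitrogen, and that step was modest though beyond the scatter. Both groups tried so far at that carbon gave numbers of the same order, and nothing tells which way pyridin-3-yl will move the read-out, so for compound 3 a step in this assay of modest size at most, in either direction, is expected, a number 6 percentage points higher from compound 2 to compound 3 (within the scatter). Compound 3 is therefore estimated to give 50% in this assay, within the range 38% to 62%.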

Compound 3, a percentage reported as inhibition, in the whole organism at one dose (the size of the read-out at that dose, not a potency): 52.4%
The estimate for compound 3 lay 2.4 percentage points below the measured number; measured number inside the range.
By their numbers in this assay, from the lowest: compounds 2, 3 and 1 (each within the scatter of the next, the first and the last beyond it).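

At the carbon with a double bond to nitrogen, pyridin-3-yl holds up in this assay with a number 8.4 percentage points higher from compound 2 to compound 3 (within the scatter) and with a number 7.1 percentage points lower from compound 1 to compound 3 (within the scatter) so compound 3 cannot be separated from either of the other two. A ring with a hetero atom is therefore accepted at this place, and the ring need not be carbon only. Compound 3 sits within the scatter of both, so the gap between compound 1 and compound 2 remains the only difference at this position beyond the scatter, and no order among the three groups can be drawn from it. No measurement at hand explains these numbers.

As far as these compounds go, whether pyridin-2-yl or pyridin-4-yl would read like pyridin-3-yl stays open. Also open, from the compounds shown here alone, is whether an aromatic ring is needed here at all, a question that cyclohexyl or a chain ending in a carboxylic acid would address.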